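The source may hold more compounds than are shown below. What is called first, only, known or untested is meant among the compounds shown, and "the series" means these compounds.

Compound 1, with the structure `CCc1ccc(Nc2cc(NC(=O)Nc3c(Cl)cccc3Cl)ncn2)cc1`, was examined in a functional assay on NCI-H226 cells (Homo sapiens) for inhibition, read by MTT assay, with a stated time of 48 h, tested at 10 uM (a higher number here means more inhibition at the concentration tested (going by the name of the read-out), a lower number less inhibition), and there compound 1 gave 39.5%. Its only measured companion, compound 2, with the structure `COc1ccc(OC)c(Nc2cc(NC(=O)Nc3c(Cl)cccc3Cl)ncn2)c1`, gave 81.7% in this assay. Compound 1 therefore stands at the lower of the two numbers available, and the gap separating it from compound 2 lies beyond the usual scatter of such measurements. Among the compounds with values here, no step between measured compounds is available for the shared core, so the two values can only be taken as they stand.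

Compound 3, with the structure `O=C(Nc1cc(Nc2ccc(F)c(Cl)c2)ncn1)Nc1c(Cl)cccc1Cl`, is yet to be measured in this assay. It differs from compound 1 in a single place: 3-chloro-4-fluorophenyl in place of 4-ethylphenyl on a nitrogen on an aromatic ring. Within the data shown here, since no measured pair shows this change, the expected step of a number 10.5 percentage points higher from compound 1 to compound 3 (beyond the scatter) in this assay is a modest rise, not confidently beyond the scatter, leaning on the fact that compound 1 gave 39.5% while the substituted aromatic ring of compound 2 gave 81.7%. For compound 3 the estimated inhibition in this assay is 50%, with a range from 20% to 80%.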

Compound 3, a percentage reported as inhibition, at one concentration (the size of the read-out at that concentration, not a potency): 47.3%
Compound 3: middle estimate off by 2.7 percentage points, on the high side; measured number inside the range.
By their numbers in this assay, from the lowest: compounds 1 and 3 (each within the scatter of the next); then compound 2.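

In this assay, replacing 4-ethylphenyl with 3-chloro-4-fluorophenyl on a nitrogen on an aromatic ring amounts to a number 7.8 percentage points higher from compound 1 to compound 3 (within the scatter), so this exchange of one substituted six-membered aromatic ring for another gives no readable change at this position. Chlorine and fluorine on the ring, in place of the ethyl chain, therefore do not bring compound 3, at 47.3%, up to the number of compound 2, at 81.7%, which shows that not every change of this ring is accompanied by a number as high as that of compound 2. Nothing available explains the size of the step from compound 1 to compound 3.

The compounds shown leave open whether the ring on this nitrogen would give a different number with a dimethylamino group, a carboxylic acid or a longer alkyl chain in place of the groups seen so far. All three compounds share the rest of their structure, so they also leave open how the number responds to a change anywhere else on the shared core.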